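A few compounds are considered here, and "the series" means these few. Any claim that something is new, unique, unknown or untested is made for them only; others in the source may bear on it.

Measured compounds in a functional assay on HT-29 cells (Homo sapiens) for antiproliferative activity, read by MTT assay, with a stated time of 24 h; a higher number here means a weaker inhibitor, a lower number a stronger inhibitor:
- compound 1, `COc1cc(OC)c(OC)cc1/C=C/C(=O)c1ccc(OC)c2c1OC(C)(C)C=C2`, gives > 10000 nM, a limit of the assay
- compound 2, `COc1ccc(C(=O)/C=C/c2ccc(N(C)C)cc2)c2c1C=CC(C)(C)O2`, gives 1870 nM
- compound 3, `COc1ccc(C(=O)/C=C/c2ccc(N(c3ccccc3)c3ccccc3)cc2)c2c1C=CC(C)(C)O2`, gives > 10000 nM, a limit of the assay

Within the data shown here, compound 2 holds the only numerical value in this assay. Compound 1 stands at the limit of > 10000 nM in this assay, at which 2 of the 3 values shown sit. Among the measured compounds shown here, compound 3 also sits at that limit; no step between measured compounds can be computed, since no pair differs in one place only, and the two limits give no size for any comparison with compound 2.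

Compound 4, `COc1ccc(C(=O)/C=C/c2ccc([N+](=O)[O-])cc2)c2c1C=CC(C)(C)O2`, differs from compound 2 in one place: nitro in place of dimethylamino on an aromatic carbon. For the measured compounds named here, no measured step informs this change, so neither direction nor size can be read from the series; the expectation below rests on compound 2 alone as the anchor.

Working expectation: compound 4 is estimated to come out somewhat weaker than compound 2 in this assay, with the step of a 2.4-fold higher number from compound 2 to compound 4 (0.38 log units; beyond the scatter) taken as modest, though a result within the scatter of compound 2 is not excluded. The estimate for compound 4 is 4500 nM, with a range from 1200 nM to 15000 nM, and a real chance that only a limit is reported.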

Compound 4, half-maximal inhibitory concentration: 3730 nM
Compound 4: the middle estimate sits 1.2-fold (0.08 log units) above what was measured; measured number inside the range.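

In this assay, among these compounds, the change from 4-(dimethylamino)phenyl to 4-nitrophenyl gives a 2.0-fold higher number from compound 2 to compound 4 (0.30 log units; within the scatter) and is the first step that can be read. This position, on an aromatic carbon para to a large group, therefore accepts nitro in place of dimethylamino with no change beyond the scatter, and a numerical value in this assay is not confined to the dimethylamino compound. Nothing measured for these compounds bears on why the two groups read alike.

Among the compounds shown here, with only two groups compared at this position, no trend can be drawn, and it remains open whether a primary amine, a carboxylic acid or a longer chain on the same aromatic carbon would stay within the scatter of compound 2. Steps involving compound 1 or compound 3 cannot be read, as each holds a limit of the assay and not a number: the limit of > 10000 nM in this assay, at which 2 of the 4 values shown sit.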